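Working notes: acetyl in place of cyanomethyl

The source may hold more compounds than are shown below. What is called first, only, known or untested is meant among the compounds shown, and "the series" means these compounds.

Measured in an ADME assay on Vero cells (Chlorocebus sabaeus) for cytotoxicity, read by MTT assay, with a stated time of 72 h; on this read-out higher numbers stand for lower toxicity in this test and lower numbers for higher toxicity in this test:
- compound 1 `COc1c(N2CCN(CC#N)C(C)C2)c(F)cc2c(=O)c(C(=O)O)cn(C3CC3)c12`: 354 ug/mL
- compound 2 `COc1c(N2CCN(CCC#N)C(C)C2)c(F)cc2c(=O)c(C(=O)O)cn(C3CC3)c12`: 500 ug/mL
- compound 3 `CCOC(=O)CN1CCN(c2c(F)cc3c(=O)c(C(=O)O)cn(C4CC4)c3c2OC)CC1C`: 1000 ug/mL

Compound 2, at 500 ug/mL, lies within the scatter of both compound 1 and compound 3. Compound 4 `COc1c(N2CCN(CC(C)=O)C(C)C2)c(F)cc2c(=O)c(C(=O)O)cn(C3CC3)c12` has acetyl in place of cyanomethyl on a saturated chain carbon bound to an amine nitrogen in a ring.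

The closest measured change is ethoxycarbonyl in place of cyanomethyl at that same place, which also puts a carbonyl in the chain: a 2.0-fold higher number from compound 2 to compound 3 (0.30 log units; within the scatter). That step stays within the scatter, as does a 1.4-fold higher number from compound 1 to compound 2 (0.15 log units; within the scatter). Only a 2.8-fold higher number from compound 1 to compound 3 (0.45 log units; beyond the scatter) goes beyond it, and modestly. Among the compounds with values here, no acetyl compound has been measured, so the guidance is thin.

A small rise at most is expected in this assay, with nothing beyond the scatter. The estimated step is a 1.3-fold higher number from compound 2 to compound 4 (0.11 log units; within the scatter). The estimated value for compound 4 is 650 ug/mL, with an expected range of 300 ug/mL to 1300 ug/mL.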

Compound 4, half-maximal cytotoxic concentration: 500 ug/mL
Estimate against measurement, compound 4: 1.3-fold (0.11 log units) above; measured number inside the range.
By their numbers in this assay, from the lowest: compounds 1, 2, 4 and 3 (each within the scatter of the next, the first and the last beyond it).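

In this assay, acetyl in place of cyanomethyl on a saturated chain carbon bound to an amine nitrogen in a ring gives no change at the digits printed from compound 2 to compound 4 (within the scatter), so at this place a nitrile is not required to keep the number at the level of compound 2. Methyl in place of ethoxy on a carbonyl carbon gives a 2.0-fold lower number from compound 3 to compound 4 (0.30 log units; within the scatter), and acetyl in place of cyano gives a 1.4-fold higher number from compound 1 to compound 4 (0.15 log units; within the scatter), so compound 4 is within the scatter of every other compound in the series, although compound 1 and compound 3 are not within the scatter of each other. No measurement shown here offers an explanation for these steps.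

The compounds shown leave open whether a carboxylic acid, an amine or a longer chain at this place would give a number beyond the scatter of compound 2. They also leave open whether the steps seen here would hold on a core carrying a different group.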